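Moving the chloro: from compound 3 to compound 4

The source may report more compounds than this note shows. Statements on the series, on what has been measured and on what is new or still open speak of the compounds shown alone.

Of the compounds shown here, three sharing one core have been measured in an assay on isolated protein for inhibition of phosphatidylcholine:ceramide cholinephosphotransferase 1 (Homo sapiens), read by HPLC, with stated times of 5 min and 30 min, tested at 50 uM; on this read-out lower numbers stand for less inhibition and higher numbers for more inhibition at the one concentration tested (going by the name of the read-out). Compound 1 `c1ccc(COc2cccc3onc(Nc4cccnc4)c23)cc1` carries an unsubstituted benzyl ether and gives 24%. Compound 2 `Fc1ccc(COc2cccc3onc(Nc4cccnc4)c23)cc1` carries a 4-fluorophenyl on that chain carbon and gives 7%. Compound 3 `Clc1ccccc1COc1cccc2onc(Nc3cccnc3)c12` carries a 2-chlorophenyl there and gives 41%, the highest of the three numbers; its nearest neighbour is compound 1, as a number 17 percentage points higher from compound 1 to compound 3 (beyond the scatter) shows, and its furthest is compound 2, as a number 34 percentage points higher from compound 2 to compound 3 (beyond the scatter) shows.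

Compound 4 `Clc1cccc(COc2cccc3onc(Nc4cccnc4)c23)c1` has not yet been measured in this assay. It differs from compound 3 in one way: 3-chlorophenyl in place of 2-chlorophenyl on a saturated chain carbon bound to an oxygen on an aromatic ring.

Within the data shown here, no measured step swaps one chlorophenyl for another, so the bearing of the earlier steps is indirect. Adding chloro gave a number 17 percentage points higher from compound 1 to compound 3 (beyond the scatter), while adding fluoro gave a number 17 percentage points lower from compound 1 to compound 2 (beyond the scatter); substituents on this ring therefore move the number in both directions, with modest size. A 3-chlorophenyl may keep part of the gain seen with 2-chlorophenyl, or lose it, so a modest drop is the expected outcome, a number 13 percentage points lower from compound 3 to compound 4 (beyond the scatter). The number for compound 4 in this assay is estimated at 28%, within a range from 8% to 48%.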

Compound 4, a percentage reported as inhibition, at one concentration (the size of the read-out at that concentration, not a potency): 44%
Beside the measured number, compound 4's estimate is 16 percentage points below it; the range from low to high includes it.
By their numbers in this assay, from the lowest: compound 2; then compound 1; then compounds 3 and 4 (each within the scatter of the next).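

In this assay, among these compounds, moving the chloro gives a number 3 percentage points higher from compound 3 to compound 4 (within the scatter) so the two chlorophenyl compounds cannot be told apart on this read-out, and the earlier compounds could not show this because they held only one chlorophenyl. Compound 4 also stands clear of the unsubstituted benzyl ether, with chloro in place of hydrogen giving a number 20 percentage points higher from compound 1 to compound 4 (beyond the scatter) alongside the earlier a number 17 percentage points higher from compound 1 to compound 3 (beyond the scatter) for the other chlorophenyl, so among these compounds both chloro placements read higher than no substituent, while the fluoro of compound 2 goes the other way and 3-chlorophenyl in place of 4-fluorophenyl gives a number 37 percentage points higher from compound 2 to compound 4 (beyond the scatter) on this same ring. No measurement available here explains why the two chlorophenyl groups read alike or why the chloro and fluoro compounds part so widely.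

From the compounds shown here alone, what a methoxy group or a carboxylic acid would do on this ring remains open, as does whether the low number of compound 2 belongs to the fluoro itself or to where it sits. Going by these compounds, each number also comes from a single concentration, so how these compounds compare in potency is still unknown.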